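Thiophene substituent change in a camphor-derived amine series

The source may report more compounds than this note shows. Statements on the series, on what has been measured and on what is new or still open speak of the compounds shown alone.

Measured so far:
compound 1, `CCc1ccc(CN[C@@H]2C[C@H]3C[C@@H]([C@H]2C)C3(C)C)s1`: 1560 nM
compound 2, `C[C@H]1[C@H](NCc2sccc2C2CCCCC2)C[C@H]2C[C@@H]1C2(C)C`: 1560 nM

In an ADME assay on MDCK cells (Canis lupus familiaris) for cytotoxicity, read by microscopy, with a stated time of 48 h (a higher number here means that more compound is tolerated, a lower number that less compound is tolerated), compound 1 gives 1560 nM and compound 2 gives 1560 nM; compound 2 stands level with compound 1 within the scatter. Compound 3, `C[C@H]1[C@H](NCc2sccc2Br)C[C@H]2C[C@@H]1C2(C)C`, differs from compound 2 by bromo in place of cyclohexyl on an aromatic carbon. Among the measured compounds shown here, no step between measured compounds bears on this change, so no direction beyond the scatter is expected. The step from compound 2 to compound 3 in this assay is estimated as no change at the digits printed from compound 2 to compound 3 (within the scatter), within the scatter. For compound 3 the expected minimum cytotoxic concentration is 1560 nM, with a range from 780 nM to 3120 nM.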

Compound 3, minimum cytotoxic concentration: 50000 nM
Compound 3: the middle estimate sits 32-fold (1.51 log units) below what was measured; the whole stated range lies below it.
By their numbers in this assay, from the lowest: compounds 1 and 2 (each within the scatter of the next); then compound 3.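

In this assay, bromo in place of cyclohexyl on this aromatic carbon, two ring bonds from the ring sulfur, gives a 32-fold higher number from compound 2 to compound 3 (1.51 log units; beyond the scatter) and is a large step. Compound 1 and compound 2 stand level, so they gave no sign that a single change here could move the read-out this far. Nothing on hand bears on why the number moves.

Still open, as far as these compounds go, is whether the step follows from the loss of cyclohexyl or from the arrival of bromo. Chloro, methyl or methoxy on this carbon would help separate the two.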